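An aryl swap on a shared core

A few compounds are considered here, and "the series" means these few. Any claim that something is new, unique, unknown or untested is made for them only; others in the source may bear on it.

Of the compounds shown here, three built on one shared core have been tested in a functional assay on B16-F10 cells (Mus musculus) for cytotoxicity; on this read-out higher numbers stand for weaker inhibition and lower numbers for stronger inhibition. Compound 1 `O=c1oc2ccccc2c2nc3c(ccc4cc[nH]c43)c(-c3ccc(C(F)(F)F)cc3)c12` gives 70700 nM, compound 2 `O=c1oc2ccccc2c2nc3c(ccc4cc[nH]c43)c(-c3cccnc3Cl)c12` gives 70700 nM, and compound 3 `O=c1oc2ccccc2c2nc3c(ccc4cc[nH]c43)c(-c3ccc(O)cc3)c12` gives 70700 nM, so compound 3 stands level with the other two.

The next compound, compound 4 `O=c1oc2ccccc2c2nc3c(ccc4cc[nH]c43)c(-c3ccccc3Br)c12`, differs from compound 3 in one place: 2-bromophenyl in place of 4-hydroxyphenyl on an aromatic carbon. In plain words, 2-bromophenyl takes the place of 4-hydroxyphenyl on an aromatic carbon, opposite the ring nitrogen.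

Two measured swaps of the whole group at this same carbon bear most directly on the change: no change at the digits printed from compound 1 to compound 2 (within the scatter), and no change at the digits printed from compound 2 to compound 3 (within the scatter). A smaller swap within the group points the same way: no change at the digits printed from compound 1 to compound 3 (within the scatter). None of these compounds carries bromine, so the new group itself remains untested. On this evidence, no step beyond the scatter is expected in this assay. The expected step is no change at the digits printed from compound 3 to compound 4 (within the scatter). Compound 4 is estimated at 70700 nM. The expected range for compound 4 runs from 25000 nM to 100000 nM.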

Compound 4, half-maximal inhibitory concentration: 70700 nM
The estimate for compound 4 equals the measured number at the digits printed, within the range that was stated.
By their numbers in this assay, from the lowest: compounds 1, 2, 3 and 4 (each within the scatter of the next).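

Within the data shown here, with 2-bromophenyl, bromine appears at this carbon opposite the ring nitrogen for the first time, and this assay shows no change at the digits printed from compound 3 to compound 4 (within the scatter). The comparisons with the other two aryl groups agree, with no change at the digits printed from compound 2 to compound 4 (within the scatter) and no change at the digits printed from compound 1 to compound 4 (within the scatter). The swap from 3 to 4 also removes the hydrogen-bond donor and acceptor counted on 4-hydroxyphenyl, yet the printed number stays the same, so this aryl set now includes a group with neither.

No measurement here explains why the four compounds read alike. Going by these compounds, how an amine, a carboxylic acid or a longer chain on this carbon would read remains open, as does whether changes elsewhere on the shared core would shift the number.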